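Lengthening the Chain Beyond Compound 2

The compounds below may be only part of what the source reports. "The series", "measured", "known", "first", "only" and "open" are said of these compounds alone.

Compound 1 (`CCCCCCCn1cc(COC[C@@H]2OC[C@H](N)[C@@H]2O)nn1`) gives > 128000 nM as a limit of the assay
Compound 2 (`CCCCCCCCCCCCn1cc(COC[C@@H]2OC[C@H](N)[C@@H]2O)nn1`) gives 21400 nM as a measured value

Going by the values given here, in a functional assay on MGC-803 cells (Homo sapiens) for antiproliferative activity, read by MTT assay, with a stated time of 48 h (a lower number here means a stronger inhibitor, a higher number a weaker inhibitor), compound 2 at 21400 nM holds the only actual number so far. The one other result, for compound 1, is a limit. Compound 3 (`CCCCCCCCCCCCCCn1cc(COC[C@@H]2OC[C@H](N)[C@@H]2O)nn1`) differs from compound 2 as follows: ethyl in place of hydrogen on a saturated chain carbon, ten or more bonds along the chain from an aromatic nitrogen and the rest of the structure stays the same. Among the compounds with values here, the one measured step bearing on this is an at least 5.9-fold lower number from compound 1 to compound 2 (0.77 log units; beyond the scatter) on the same chain, and with a limit at one end its true size remains open. Ethyl is a smaller addition than pentyl, so a smaller step in the same direction is expected in this assay toward a lower number, although a single step cannot show that the trend continues. The expected change is a 1.8-fold lower number from compound 2 to compound 3 (0.25 log units; within the scatter) as an estimate. For compound 3 the estimated value is 12000 nM with an expected range from 4000 nM to 40000 nM in this assay.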

Compound 3, half-maximal inhibitory concentration: 8210 nM
Beside the measured number, compound 3's estimate is 1.5-fold (0.16 log units) above it, within the range that was stated.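

In this assay, ethyl in place of hydrogen on a saturated chain carbon gives a 2.6-fold lower number from compound 2 to compound 3 (0.42 log units; beyond the scatter). This is the first step along this chain with a measured number at both ends, and it shows that the lowering of the number continues at this far position, with no compound shown going against it. Across the whole run the change is an at least 15-fold lower number from compound 1 to compound 3 (1.19 log units; beyond the scatter), but its true size stays open since compound 1 gives only a limit of the assay: the limit of > 128000 nM in this assay, at which 1 of the 3 values shown sits.

The compounds shown leave open whether a longer chain would lower the number further or reverse the trend. They also leave open how a hydroxyl, an amine or a carboxylic acid at the far end of the chain would change it.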